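Chain length at the acid arm of the amidine series

The source may report more compounds than this note shows. Statements on the series, on what has been measured and on what is new or still open speak of the compounds shown alone.

Compound 3 `N=C(N)c1ccc(C(=O)N2CCC3(CCN(C(=O)CC(=O)O)CC3)CC2)cc1` gives 9300 nM in a functional assay for inhibition, with Homo sapiens as the target; a lower number here means a stronger inhibitor, a higher number a weaker inhibitor. Among the three measured compounds it stands second highest; its nearest neighbour is compound 2 `N=C(N)c1ccc(C(=O)N2CCC3(CCN(C(=O)CCCC(=O)O)CC3)CC2)cc1`, which gives 10300 nM, a gap within the scatter, and the furthest is compound 1 `Cc1noc(C)c1S(=O)(=O)N[C@@H](CNC(=O)N1CCC2(CC1)CCN(c1ccncc1)CC2)C(=O)O`, which gives 39 nM, a gap well beyond it.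

Compound 4 `N=C(N)c1ccc(C(=O)N2CCC3(CCN(C(=O)CCCCC(=O)O)CC3)CC2)cc1` differs from compound 3 by 3-carboxypropyl in place of carboxy on a saturated chain carbon bound to a carbonyl carbon. Among the compounds with values here, the only measured step that bears on this is the earlier shortening of the same chain, a 1.1-fold lower number from compound 2 to compound 3 (0.04 log units; within the scatter), which lay within the scatter. Compound 4 carries the acid out further than compound 2 does, but with nothing more than a within-scatter step to go on, no step beyond the scatter is expected in this assay in either direction.

For compound 4 the expected value in this assay is 9500 nM, with a range from 4000 nM to 25000 nM. This expectation amounts to an estimated step of a 1.0-fold higher number from compound 3 to compound 4 (0.01 log units; within the scatter), within the scatter.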

Compound 4, half-maximal inhibitory concentration: 18800 nM
For compound 4 the middle estimate is 2.0-fold (0.30 log units) below the measured one; the measured number falls inside the stated range.
By their numbers in this assay, from the lowest: compound 1; then compounds 3, 2 and 4 (each within the scatter of the next, the first and the last beyond it).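

In this assay, within the data shown here, the acid arm is not as flat as the earlier pair suggested: 3-carboxypropyl in place of carboxy gives a 2.0-fold higher number from compound 3 to compound 4 (0.31 log units; beyond the scatter), a modest loss of inhibition and the only step at this position beyond the scatter. The intermediate chain does not separate from the longest, with a 1.8-fold higher number from compound 2 to compound 4 (0.26 log units; within the scatter), so the chain length registers only across the full span, and compound 2 cannot be ordered against either neighbour. No measurement at hand accounts for this step.

Going by these compounds, whether a longer chain would raise the number further remains open, as the span so far is small and the step modest. Also open, on these data alone, is whether an amine or a tetrazole at the chain end, in place of the carboxylic acid, would keep this level of inhibition.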